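The compounds below may be only part of what the source reports. "The series", "measured", "known", "first", "only" and "open" are said of these compounds alone.

Of the compounds shown here, three have been measured in a functional assay on PC-3 cells (Homo sapiens) for inhibition, read by sulforhodamine B assay, with a stated time of 48 h, tested at 50 uM; a lower number here means less inhibition of growth, a higher number more inhibition of growth at the concentration tested. Compound 1 `COc1cc2c(cc1CC=C(C)C)/C(=N/NC(N)=O)C[C@@H](c1ccc(O)cc1)O2` gives 67%, compound 2 `COc1ccc([C@@H]2C/C(=N/OCc3cn(-c4ccc(Cl)cc4C)nn3)c3cc(CC=C(C)C)c(OC)cc3O2)cc1` gives 49%, and compound 3 `COc1cc2c(cc1CC=C(C)C)C(=O)C[C@@H](c1ccc(Oc3ccccc3)cc1)O2` gives 53%. Compound 3 thus stands second highest of the three: compound 2 is its nearest neighbour, within the usual scatter, while compound 1 lies beyond the scatter above it. Compound 4 `CCOc1ccc([C@@H]2CC(=O)c3cc(CC=C(C)C)c(OC)cc3O2)cc1` awaits measurement in this assay. It differs from compound 3 in one place, (ethyl in place of phenyl on an oxygen on an aromatic ring); the same difference, cut one bond further out, reads phenoxy to ethoxy. Going by the values given here, no measured pair follows this change, so the expected step of a number 3 percentage points lower from compound 3 to compound 4 (within the scatter) is small, downward if anything, and not clearly beyond the scatter. Compound 4 is therefore estimated at 50%, within a range from 35% to 65%.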

Compound 4, percent growth inhibition at one concentration: 60%
For compound 4 the middle estimate is 10 percentage points below the measured one; the measured number falls inside the stated range.
By their numbers in this assay, from the lowest: compounds 2, 3, 4 and 1 (each within the scatter of the next, the first and the last beyond it).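

In this assay, ethyl in place of phenyl on an oxygen on an aromatic ring gives a number 7 percentage points higher from compound 3 to compound 4 (within the scatter). For this pair, the position therefore keeps growth inhibition at the tested concentration without the aromatic ring on that oxygen, even though the group entering is much smaller than the one leaving. No measurement shown here accounts for the step. On these data alone, whether a longer chain such as butyl on that oxygen, or an aminoethyl group, would keep this level remains open.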